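This account rests on a few compounds, and the source may have more. Where it says the series, first, only, none or still open, it means among the compounds named here.

Measured compounds in this series:

Compound 1, `N#Cc1c(-c2ccc(O)cc2)c(C#N)c(=O)n(/N=C/c2cn(-c3ccccc3)nc2-c2ccccc2)c1N`. In an ADME assay on HeLa cells (Homo sapiens) for cytotoxicity, read by MTT assay (a lower number here means a stronger inhibitor, a higher number a weaker inhibitor), compound 1 gives > 200 ug/mL, which is a limit of the assay and not a number.
Compound 2, `N#Cc1c(-c2cccc(F)c2)c(C#N)c(=O)n(/N=C/c2cn(-c3ccccc3)nc2-c2ccccc2)c1N`. In this assay compound 2 gives > 200 ug/mL, again a limit of the assay.
Compound 3, `COc1cc(-c2c(C#N)c(N)n(/N=C/c3cn(-c4ccccc4)nc3-c3ccccc3)c(=O)c2C#N)cc(OC)c1OC`. In this assay compound 3 gives > 200 ug/mL, also a limit of the assay.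

Compound 1 therefore stands at a limit only, and the two further values shown are limits as well: the limit of > 200 ug/mL in this assay, at which 3 of the 3 values shown sit. The steps that differ in one place from compound 1 are a step that the two limits leave unreadable from compound 1 to compound 2 and a step that the two limits leave unreadable from compound 1 to compound 3; the remaining step, a step that the two limits leave unreadable from compound 2 to compound 3, is likewise unreadable. Among the measured compounds shown here, no measured step in this assay gives a size or a direction.

The next compound, compound 4, `N#Cc1c(-c2ccc([N+](=O)[O-])cc2)c(C#N)c(=O)n(/N=C/c2cn(-c3ccccc3)nc2-c2ccccc2)c1N`, differs from compound 1 as follows: nitro in place of hydroxy on an aromatic carbon. The closest measured steps, from compound 1 to compound 2 and from compound 1 to compound 3, both exchange the group on the same aromatic carbon and both end at the limit. No step beyond the scatter is therefore expected in this assay, and the value for compound 4 is expected to sit at the limit as well, meaning an expected step that the limit leaves unreadable from compound 1 to compound 4. The estimate for compound 4 in this assay is 250 ug/mL, with a range from 100 ug/mL to 800 ug/mL.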

Compound 4, half-maximal inhibitory concentration: > 200 ug/mL
Compound 4 ended at the assay's limit (the forecaster's own chance of this, stated with the estimate: 85%); the middle value does not contradict the limit.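

Compound 4 gives a limit of the assay and not a number, so no step from compound 1, compound 2 or compound 3 to compound 4 can be read: the limit of > 200 ug/mL in this assay, at which 4 of the 4 values shown sit.

The compounds shown leave open whether compounds 1, 2, 3 and 4 differ at all in this assay, and which group on the shared core, if any, gives a readable value.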